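Swapping the benzyl group for a thiourea-linked fluorophenyl

The source may hold more compounds than are shown below. What is called first, only, known or untested is meant among the compounds shown, and "the series" means these compounds.

Compound 2 `NC(=O)c1c(NC(=O)c2ccccc2Cl)sc2c1CCN(Cc1ccc(Cl)cc1Cl)C2` carries a 2,4-dichlorobenzyl group on the ring amine nitrogen of the shared core. Going by the values given here, in a functional assay on MKN-74 cells (Homo sapiens) for antiproliferative activity, with a stated time of 24 h (on this read-out lower numbers stand for stronger inhibition and higher numbers for weaker inhibition), compound 2 gives 16300 nM, the highest of the two numbers measured so far. Its nearest neighbour is compound 1 `N#Cc1ccccc1CN1CCc2c(sc(NC(=O)c3ccccc3Cl)c2C(N)=O)C1`, which differs only in bearing a 2-cyanophenyl group at the same position and which in this assay gives 9500 nM; the step of a 1.7-fold higher number from compound 1 to compound 2 (0.23 log units; within the scatter).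

Compound 3 `NC(=O)c1c(NC(=O)c2ccccc2Cl)sc2c1CCN(C(=S)Nc1ccccc1F)C2` has not yet been measured in this assay. Relative to compound 2 it introduces (a group of 10 heavy atoms (7 carbon, 1 nitrogen, 1 fluorine, 1 sulfur; one six-membered aromatic ring of carbon only) in place of a group of 9 heavy atoms (7 carbon, 2 chlorine; one six-membered aromatic ring of carbon only), on an amine nitrogen in a ring). Among the compounds with values here, the only measured step that touches this position is the one from compound 1 to compound 2, and it stayed within the scatter, so there is no evidence yet that changing the substituent on the ring amine nitrogen moves the number in either direction. The group entering compound 3 is of a different kind from either of the measured substituents, so the expectation rests on thin ground.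

On that basis the step of a 1.4-fold lower number from compound 2 to compound 3 (0.13 log units; within the scatter) is expected to be small. Compound 3 is therefore estimated at 12000 nM, with a plausible range from 3000 nM to 45000 nM.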

Compound 3, half-maximal inhibitory concentration: 12600 nM
Compound 3: middle estimate off by 1.1-fold (0.02 log units), on the low side; the range from low to high includes it.
By their numbers in this assay, from the lowest: compounds 1, 3 and 2 (each within the scatter of the next).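

On the amine nitrogen in a ring, a group with 1 hydrogen-bond donor, 1 hydrogen-bond acceptor and 1 double bond outside aromatic rings, none of which the 2,4-dichlorobenzyl group has, gives a step of a 1.3-fold lower number from compound 2 to compound 3 (0.11 log units; within the scatter) in this assay. Read against the 2-cyanophenyl group, the same entering group gives a 1.3-fold higher number from compound 1 to compound 3 (0.12 log units; within the scatter), so all three substituents now lie within the scatter of one another, and the position shows no step beyond the scatter even with a thiourea-linked group in place of a benzyl-type one. No measurement at hand bears on why these numbers lie so close together.

The compounds shown do not tell whether any substituent on this nitrogen can move the number beyond the scatter. Going by these compounds, whether an amine or a carboxylic acid on the phenyl ring of the entering group, or a longer chain on the ring amine nitrogen, would do so remains open.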